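Swapping the Aryl Group on a Sulfonamide Nitrogen

This account rests on a few compounds, and the source may have more. Where it says the series, first, only, none or still open, it means among the compounds named here.

Compound 1 `CCc1ccc(NS(=O)(=O)c2ccc(N3CCNC3=O)cc2)cc1` was tested in a functional assay on MCF7 cells (Homo sapiens) for antiproliferative activity, read by sulforhodamine B assay, with a stated time of 48 h (a lower number here means a stronger inhibitor, a higher number a weaker inhibitor), where compound 1 gives 810 nM. Among the values gathered here this is the only one reported as a number. Compound 2 `CCCCCCOc1ccc(NS(=O)(=O)c2ccc(N3CCNC3=O)cc2)cc1` gives > 1000 nM in this assay, which is a limit of the assay rather than a number. The step of an at least 1.2-fold higher number from compound 1 to compound 2 (0.09 log units; that floor lies within the scatter) has only a floor because of the limit of > 1000 nM in this assay, at which 1 of the 2 values shown sits.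

Compound 3 `Cc1ccc(C)c(NS(=O)(=O)c2ccc(N3CCNC3=O)cc2)c1` has not been measured. It differs from compound 1 in a single change, (2,5-dimethylphenyl in place of 4-ethylphenyl on a sulfonamide nitrogen), the two structures holding the same atoms joined differently. Among the measured compounds shown here, no measured step concerns this change: the only step in hand, from compound 1 to compound 2, exchanges a different group and ends at a limit, so it offers no guide to the size or direction of the move to compound 3. The reasonable expectation is therefore no step beyond the usual scatter. Compound 3 is expected to give 900 nM in this assay, with a range from 400 nM to 2500 nM. That corresponds to an expected step of a 1.1-fold higher number from compound 1 to compound 3 (0.05 log units; within the scatter).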

Compound 3, half-maximal inhibitory concentration: 48 nM
Estimate against measurement, compound 3: 19-fold (1.27 log units) above; measured number below the stated range.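

In this assay, among the compounds shown here, the aryl group on the sulfonamide nitrogen now proves able to move the number a long way: the step is a 17-fold lower number from compound 1 to compound 3 (1.23 log units; beyond the scatter), whereas the one earlier step, an at least 1.2-fold higher number from compound 1 to compound 2 (0.09 log units; that floor lies within the scatter), ended at a limit and showed no move beyond the scatter. The 4-ethylphenyl and 2,5-dimethylphenyl groups match in everything counted, namely heavy atoms, aromatic ring, hydrogen-bond donors and acceptors, and charge, so what separates compound 1 from compound 3 is how the same atoms are arranged, not how many there are. Nothing measured here gives a reason for the size of this step.

The compounds shown leave open whether the lower number of compound 3 rests on one of its two methyl groups or requires both, since no compound carries either methyl group alone. They also leave open how the same place would respond to a chlorine, a methoxy group or an amine on the ring, and whether the step would hold with the 2,5-dimethylphenyl group on a changed core.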